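The compounds below may be only part of what the source reports. "The series", "measured", "known", "first", "only" and "open" are said of these compounds alone.

Measured compounds in a functional assay on A549 cells (Homo sapiens) for antiproliferative activity, read by CCK-8 assay, with a stated time of 72 h; a higher number here means a weaker inhibitor, a lower number a stronger inhibitor:
compound 1 `O=C(Nc1cccc(-c2oc3cc(-c4ccc(F)cc4)ccc3c(=O)c2O)c1)c1ccccc1F` gives 4410 nM;
compound 2 `COc1ccc(C(=O)Nc2cccc(-c3oc4cc(-c5ccc(F)cc5)ccc4c(=O)c3O)c2)cc1` gives 8700 nM;
compound 3 `Cc1ccc(C(=O)Nc2cccc(-c3oc4cc(-c5ccc(F)cc5)ccc4c(=O)c3O)c2)cc1` gives 6910 nM.

The three share one core and differ only in the aryl group on the amide carbonyl. Compound 3 sits second highest among these three numbers, but all three lie within the scatter of one another: a 2.0-fold higher number from compound 1 to compound 2 (0.30 log units; within the scatter), a 1.6-fold higher number from compound 1 to compound 3 (0.20 log units; within the scatter), a 1.3-fold lower number from compound 2 to compound 3 (0.10 log units; within the scatter). Compound 4 `O=C(Nc1cccc(-c2oc3cc(-c4ccc(F)cc4)ccc3c(=O)c2O)c1)c1ccc(F)cc1F` carries the change (2,4-difluorophenyl in place of 4-methylphenyl on a carbonyl carbon). The closest guide is compound 1, where a single fluorine on the carbonyl-bound ring gave a number within scatter of compound 3. Among the measured compounds shown here, no measured step exceeds the scatter, so compound 4 is expected to stay in the same band, with at most a small drift downward: a 1.5-fold lower number from compound 3 to compound 4 (0.19 log units; within the scatter). The estimate for compound 4 in this assay is 4500 nM, with a likely range from 2000 nM to 10000 nM.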

Compound 4, half-maximal inhibitory concentration: 20500 nM
For compound 4 the middle estimate is 4.6-fold (0.66 log units) below the measured one, outside the stated range (above it).
By their numbers in this assay, from the lowest: compounds 1, 3 and 2 (each within the scatter of the next); then compound 4.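

In this assay, the aryl group on this carbonyl carbon had shown no step beyond the scatter, but 2,4-difluorophenyl does, both against 4-methylphenyl (a 3.0-fold higher number from compound 3 to compound 4 (0.47 log units; beyond the scatter)) and against 4-methoxyphenyl (a 2.4-fold higher number from compound 2 to compound 4 (0.37 log units; beyond the scatter)). The largest step comes from fluoro in place of hydrogen on an aromatic carbon (a 4.6-fold higher number from compound 1 to compound 4 (0.67 log units; beyond the scatter)), so a single atom change on this ring can weaken the compound more than the earlier swaps of the aryl group did.

Nothing shown gives a cause for this rise. From the compounds shown here alone, whether a chloro group, an amine or a carboxylic acid on this aryl ring would shift the number in the same way stays open.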